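This account rests on a few compounds, and the source may have more. Where it says the series, first, only, none or still open, it means among the compounds named here.

Measured so far:
- compound 1, `CCC(=O)Nc1ccc(-c2nc3cc(C(F)(F)F)ccc3[nH]2)cc1`: > 100000 nM
- compound 2, `O=C(CN1CCCC1)Nc1ccc(-c2nc3ccccc3[nH]2)cc1`: > 100000 nM

In an ADME assay on Vero cells (Chlorocebus sabaeus) for cytotoxicity (a higher number here means that more compound is tolerated, a lower number that less compound is tolerated), compound 1 gives > 100000 nM, which is a limit of the assay and not a number. In this assay compound 2 also gives > 100000 nM, again a limit rather than a number. For the measured compounds named here, the only evidence bearing on the series in this assay is the limit of > 100000 nM in this assay, at which 2 of the 2 values shown sit. Compound 2 therefore stands at the top of what the assay reports, and nothing in these two values separates it from compound 1.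

Compound 3, `O=C(CN1CCCCC1)Nc1ccc(-c2nc3ccccc3[nH]2)cc1`, is to be measured in this assay. It differs from compound 2 by piperidin-1-yl in place of pyrrolidin-1-yl on a saturated chain carbon bound to a carbonyl carbon. Going by the values given here, no step between measured compounds is known here, so the size of the change is untested. Given the limit of > 100000 nM in this assay, at which 2 of the 2 values shown sit, for compound 2, the expected step from compound 2 to compound 3 in this assay is none beyond the scatter, a step that the limit leaves unreadable from compound 2 to compound 3. Compound 3 is accordingly estimated at 150000 nM, with an expected range of 70000 nM to 400000 nM, most likely reported again as a limit.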

Compound 3, half-maximal cytotoxic concentration: > 100000 nM
Compound 3: a limit, no number (the forecaster's own chance of this, stated with the estimate: 85%); the middle value lies beyond the limit too.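

For the compounds shown here, no step can be read between compound 2 and compound 3 in this assay, and the only evidence on the series is this: the limit of > 100000 nM in this assay, at which 3 of the 3 values shown sit. Still open, going by these compounds, is how much compound each of the three tolerated compounds would take before cytotoxicity appears, and whether piperidin-1-yl and pyrrolidin-1-yl differ at all.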